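Changing one stereocentre: from compound 3 to compound 4

The compounds below may be only part of what the source reports. "The series", "measured", "known", "first", "only" and "open" are said of these compounds alone.

Three related compounds have been tested in a functional assay on A549 cells (Homo sapiens) for cytotoxicity, read by MTT assay, with a stated time of 48 h; on this read-out higher numbers stand for weaker inhibition and lower numbers for stronger inhibition. Compound 3 `CCOC(=O)[C@@]1(C(=O)NCc2ccc(C)cc2)C[C@H]1c1cc(OC)c(OC)c(OC)c1` gives 17100 nM, and compound 1 `COc1cc([C@@H]2C[C@]2(CO)C(=O)NCc2ccc(C)cc2)cc(OC)c1OC` gives 10500 nM; these two values lie within the usual scatter of each other. Compound 2 `CCOC(=O)[C@]1(C(=O)Nc2ccccc2)C[C@H]1c1cc(OC)c(OC)c(OC)c1` gives 37300 nM, a number beyond the scatter from compound 3 and so a sign of weaker inhibition. All three values show modest cell-killing strength on this read-out.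

The next molecule is compound 4 `CCOC(=O)[C@]1(C(=O)NCc2ccc(C)cc2)C[C@H]1c1cc(OC)c(OC)c(OC)c1`, and it differs from compound 3 in the subtlest way possible: the two compounds have the same atoms and bonds and differ only in configuration as drawn: 1 of 2 stereo elements differ; a stereocentre at a saturated ring carbon is drawn S in compound 3 and R in compound 4. The two compounds have the same atoms and bonds and differ only in configuration as drawn, with a stereocentre at a saturated ring carbon drawn S in compound 3 and R in compound 4.

Among the measured compounds shown here, none of the measured pairs isolates a single change, so the data do not show how much this configuration matters in this assay. With no such evidence, no shift beyond the scatter is expected, and the estimated 1.2-fold higher number from compound 3 to compound 4 (0.07 log units; within the scatter) is small and has no firm direction. The estimate for compound 4 is 20000 nM, with an expected range of 8000 nM to 50000 nM.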

Compound 4, half-maximal inhibitory concentration: 13300 nM
For compound 4 the middle estimate is 1.5-fold (0.18 log units) above the measured one; measured number inside the range.
By their numbers in this assay, from the lowest: compounds 1, 4 and 3 (each within the scatter of the next); then compound 2.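

In this assay, inverting this one stereocentre gives a 1.3-fold lower number from compound 3 to compound 4 (0.11 log units; within the scatter), so the assay does not separate the two forms, and this comparison tests configuration alone because no other feature differs: the fact that compounds 3 and 4 differ only in the configuration as drawn. Among the compounds shown here, compound 4 also provides the first single-change comparisons for the other two places: 4-methylbenzyl in place of phenyl on an amide-type nitrogen gives a 2.8-fold lower number from compound 2 to compound 4 (0.45 log units; beyond the scatter), whereas ethoxycarbonyl in place of hydroxymethyl on a saturated ring carbon gives a 1.3-fold higher number from compound 1 to compound 4 (0.10 log units; within the scatter). Among these three single changes, only the change on the amide-type nitrogen moves the number beyond the scatter, and that gain in inhibition is modest.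

As far as these compounds go, the second stereocentre is drawn the same way in compound 3 and compound 4, so its own contribution remains open, as does whether configuration would matter with hydroxymethyl on the ring carbon, as in compound 1. From the compounds shown here alone, it is also open how a carboxylic acid or an amine in place of ethoxycarbonyl, or a longer chain in place of 4-methylbenzyl on the amide-type nitrogen, would shift the number.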